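The source may report more compounds than this note shows. Statements on the series, on what has been measured and on what is new or still open speak of the compounds shown alone.

Measured compounds in an assay on isolated protein for inhibition of aldehyde dehydrogenase 1A1 (Homo sapiens); on this read-out higher numbers stand for weaker inhibition and lower numbers for stronger inhibition: compound 1 `CC(Sc1nc2c(cnn2C)c(=O)n1-c1ccccc1)c1ccccn1` gives 242 nM; compound 2 `CCC(Sc1nc2c(cnn2C)c(=O)n1-c1ccccc1)c1ccccc1` gives 150 nM.

Within the data shown here, compound 2 holds the lowest of the two numbers, but its only neighbour is compound 1, and the step of a 1.6-fold lower number from compound 1 to compound 2 (0.21 log units; within the scatter) lies within the scatter, so the two compounds cannot be put in order on these data.

The next compound, compound 3 `CC(Sc1nc2c(cnn2C)c(=O)n1-c1ccccc1)c1cccc(F)c1`, has not yet been measured. It differs from compound 2 in one place: 1-(3-fluorophenyl)ethyl in place of 1-phenylpropyl on a sulfur. Among the measured compounds shown here, the one measured step that touches the same sulfur, a 1.6-fold lower number from compound 1 to compound 2 (0.21 log units; within the scatter), swapped the whole substituent and stayed within the scatter. For the measured compounds named here, no measured pair shows a fluorine added to the phenyl ring, and none shows the 1-phenylpropyl shortened to a 1-phenylethyl on its own, so there is no step that bears directly on the change. Going by the values given here, with the one nearby step being small, compound 3 is expected to differ from compound 2 by no more than the scatter, in the sense a 1.3-fold higher number from compound 2 to compound 3 (0.12 log units; within the scatter). Compound 3 is therefore estimated at 200 nM in this assay, within a range from 80 nM to 500 nM.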

Compound 3, half-maximal inhibitory concentration: 151 nM
Compound 3: the middle estimate sits 1.3-fold (0.12 log units) above what was measured; low and high end bracket the measured number.
By their numbers in this assay, from the lowest: compounds 2, 3 and 1 (each within the scatter of the next).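

In this assay, putting 1-(3-fluorophenyl)ethyl in place of 1-phenylpropyl on the sulfur gives a 1.0-fold higher number from compound 2 to compound 3 (0.00 log units; within the scatter), so a step that alters both the chain and the ring leaves the number within the scatter. The other new comparison, 3-fluorophenyl in place of pyridin-2-yl on the saturated chain carbon, gives a 1.6-fold lower number from compound 1 to compound 3 (0.20 log units; within the scatter) and also stays within the scatter, so all three substituents on this sulfur now lie within the scatter of one another and no change here has yet moved the number beyond it. No separate measurement accompanies these numbers that could account for them.

The compounds shown leave open what the fluorine and the shorter chain each contribute, as the two changes are joined in a single step and an unsubstituted 1-phenylethyl group would be needed to separate them. They also leave open how far this tolerance extends, for instance whether a longer chain such as 1-phenylbutyl, or an amine or a carboxylic acid on the phenyl ring, would carry the number beyond the scatter.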